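Hydroxy to nitro on the compound 1 aryl ring

The source may report more compounds than this note shows. Statements on the series, on what has been measured and on what is new or still open speak of the compounds shown alone.

In a functional assay on A549 cells (Homo sapiens) for antiproliferative activity, read by sulforhodamine B assay, with a stated time of 48 h (on this read-out higher numbers stand for weaker inhibition and lower numbers for stronger inhibition), compound 1 (`COc1cc(OC)c2sc(-c3ccc(N/C=C\C(=O)c4ccc(OC)c(O)c4)c(C)c3)nc2c1`) gives 14300 nM. Compound 2 (`COc1ccc(C(=O)/C=C\Nc2ccc(-c3nc4cc(OC)c(OC)c(OC)c4s3)cc2C)cc1O`) gives 15400 nM, and compound 3 (`COc1ccc2nc(-c3ccc(N/C=C\C(=O)c4ccc(OC)c(O)c4)c(C)c3)sc2c1`) gives 18000 nM. Compound 1 therefore stands within the scatter of both others, and the three values form one flat group.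

Compound 4 (`COc1cc(OC)c2sc(-c3ccc(N/C=C\C(=O)c4ccc(OC)c([N+](=O)[O-])c4)c(C)c3)nc2c1`) remains unmeasured. Its change from the parent is nitro in place of hydroxy on an aromatic carbon, ortho to a methoxy group, turning 3-hydroxy-4-methoxyphenyl into 4-methoxy-3-nitrophenyl.

Going by the values given here, only one measured step is available: a 1.1-fold higher number from compound 1 to compound 2 (0.03 log units; within the scatter), methoxy in place of hydrogen on an aromatic carbon. It stays within the scatter, but it leaves the 3-hydroxy-4-methoxyphenyl untouched. All three measured compounds keep that hydroxy, so the data give no direct size for this exchange.

A small move toward a higher number in this assay is expected, with wide uncertainty, and the estimated step is a 1.4-fold higher number from compound 1 to compound 4 (0.15 log units; within the scatter). For compound 4 the estimated value is 20000 nM, with an expected range from 7000 nM to 60000 nM.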

Compound 4, half-maximal inhibitory concentration: 12100 nM
Compound 4: middle estimate off by 1.7-fold (0.22 log units), on the high side; measured number inside the range.
By their numbers in this assay, from the lowest: compounds 4, 1, 2 and 3 (each within the scatter of the next).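

Nitro in place of hydroxy, ortho to a methoxy group, is the first variation shown on the 3-hydroxy-4-methoxyphenyl ring, and in this assay it gives a 1.2-fold lower number from compound 1 to compound 4 (0.07 log units; within the scatter). For this pair, the hydroxy with its hydrogen-bond donor can be replaced by a larger nitro group carrying no donor, and compound 4 stays in the same flat group as the three hydroxy compounds. No measurement available here bears on why the two compounds read alike.

Going by these compounds, it remains open whether a different group at this position, such as an amine or a carboxylic acid, would stay in this group or leave it. It is also open whether the nitro group would read the same on the cores of compound 2 and compound 3, which are shown only with the hydroxy.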